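The source may report more compounds than this note shows. Statements on the series, on what has been measured and on what is new or still open speak of the compounds shown alone.

Measured so far:
compound 1 `COc1cc2c(Oc3ccc(NC(=O)c4cn(-c5ccccc5C)nn4)cc3F)ccnc2cc1OCCCN1CCCC1`: "not determined" (no result reported) in a functional assay on MKN-45 cells (Homo sapiens) for cytotoxicity, read by MTT assay, with a stated time of 72 h; a lower number here means a stronger inhibitor, a higher number a weaker inhibitor
compound 2 `COc1cc2c(Oc3ccc(NC(=O)c4cn(-c5ccccc5C)nn4)cc3F)ccnc2cc1OCCCN1CCCCC1`: 3250 nM

Among the measured compounds shown here, compound 2 is the only compound here with a number in this assay, so it is the sole reference point; compound 1 supplies no value to set beside it. Compound 3 `COc1cc2c(Oc3ccc(NC(=O)c4cn(-c5ccc(F)c(F)c5)nn4)cc3F)ccnc2cc1OCCCN1CCCCC1` carries 3,4-difluorophenyl in place of 2-methylphenyl on an aromatic nitrogen. For the measured compounds named here, no measured pair tells how this kind of exchange shifts the readout, so the step from compound 2 to compound 3 is expected to stay small, likely within the usual scatter, with at most a slight gain in potency, as a 1.6-fold lower number from compound 2 to compound 3 (0.21 log units; within the scatter). Compound 3 is therefore expected to give about 2000 nM, plausibly between 500 nM and 8000 nM.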

Compound 3, half-maximal inhibitory concentration: 310 nM
Compound 3: the middle estimate sits 6.5-fold (0.81 log units) above what was measured, outside the stated range (below it).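

In this assay the group on the aromatic nitrogen of the five-membered ring proves to matter: 3,4-difluorophenyl in place of 2-methylphenyl gives a 10-fold lower number from compound 2 to compound 3 (1.02 log units; beyond the scatter) as a large step. Compound 2 alone could not show that this position responds so strongly to a change of substituted phenyl. Nothing measured here explains the gain.

Going by these compounds, the exchange removes the methyl and adds both fluorines at once, so their separate shares remain unknown. Plain phenyl or 4-fluorophenyl at this position would help separate them, and whether a non-aromatic group such as cyclohexyl is tolerated stays open.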